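Ring-to-methylamino amide change at the saturated ring carbon

The source may report more compounds than this note shows. Statements on the series, on what has been measured and on what is new or still open speak of the compounds shown alone.

Measured compounds:
- compound 1 `C[C@@H]1N[C@H](C(=O)N2CCC[C@H]2C#N)C[C@@H]1C(=O)N1CCOCC1`: 85%
- compound 2 `C[C@@H]1N[C@H](C(=O)N2CCC[C@H]2C#N)C[C@@H]1C(=O)N1CCCC1`: 88%
- compound 3 `N#C[C@@H]1CCCN1C(=O)[C@@H]1C[C@H](C(=O)N2CCCCC2)CN1`: 50%

In an assay on the whole organism (plasma, strain Sprague-Dawley) for inhibition of Dipeptidyl peptidase 4 (Rattus norvegicus), with a stated time of 10 h, at a dose of 1 mg/kg by the oral route (on this read-out lower numbers stand for less inhibition and higher numbers for more inhibition at the one dose given (going by the name of the read-out)), compound 3 gives the lowest of the three numbers; compound 1 gives 85% and compound 2 gives 88%, both well beyond the scatter above it. Compound 4 `CNC(=O)[C@@H]1CN[C@H](C(=O)N2CCC[C@H]2C#N)C1` differs from compound 3 by methylamino in place of piperidin-1-yl on a carbonyl carbon. Going by the values given here, the only measured step of a related kind is a number 3 percentage points higher from compound 1 to compound 2 (within the scatter), an exchange of one ring amide for another on a different core; no measured step replaces a ring amide with an open-chain one. That step gives no ground to expect a move beyond the scatter, so compound 4 is estimated near compound 3, with wide uncertainty: the expected step is a number 5 percentage points lower from compound 3 to compound 4 (within the scatter). Compound 4 is therefore estimated at 45%, between 20% and 70%.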

Compound 4, a percentage reported as inhibition, in the whole organism at one dose (the size of the read-out at that dose, not a potency): 28%
Compound 4: the middle estimate sits 17 percentage points above what was measured; measured number inside the range.
By their numbers in this assay, from the lowest: compound 4; then compound 3; then compounds 1 and 2 (each within the scatter of the next).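

In this assay, methylamino in place of piperidin-1-yl on a carbonyl carbon gives a number 22 percentage points lower from compound 3 to compound 4 (beyond the scatter), so at this place an open-chain amide does not match the ring amide. The ring-for-ring exchange on the core of compound 1 gave only a number 3 percentage points higher from compound 1 to compound 2 (within the scatter), but on a different core, so it sets no direct comparison. No available evidence bears on the reason for the change. Still open, on these data alone, is whether dimethylamino or a longer chain such as propylamino on this carbonyl carbon reads closer to compound 3 or to compound 4, and how a carboxylic acid there would read.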